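Two Amides and a Hydroxyl on a Shared Core

This account rests on a few compounds, and the source may have more. Where it says the series, first, only, none or still open, it means among the compounds named here.

Compound 1 `NC(=O)CCC1CCN(c2nc(-c3cc(F)c(Cl)cc3F)nc3c2CS(=O)(=O)C3)CC1`: 18 nM in a functional assay on HEK293 cells for agonist activity at Glucose-dependent insulinotropic receptor (Homo sapiens), read by reporter gene assay and cAMP accumulation, with a stated time of 6 h; on this read-out higher numbers stand for an effect only at larger amounts of compound and lower numbers for an effect already at smaller amounts
Compound 2 `NC(=O)CN1CCN(c2nc(-c3cc(F)c(Cl)cc3F)nc3c2CS(=O)(=O)C3)CC1`: 44 nM in this assay

Compound 2 has the highest of the two numbers in this assay; compound 1 gives a lower number, and that gap lies beyond the usual scatter. Compound 3 `O=S1(=O)Cc2nc(-c3cc(F)c(Cl)cc3F)nc(N3CCC(O)CC3)c2C1` has not been measured. It differs from compound 2 in one place: 4-hydroxypiperidin-1-yl in place of 4-(carbamoylmethyl)piperazin-1-yl on an aromatic carbon. Within the data shown here, no measured pair shows this change, so its effect is unknown from the data. The number for compound 3 is expected to rise a little, possibly not beyond the scatter, giving a 1.4-fold higher number from compound 2 to compound 3 (0.13 log units; within the scatter). Compound 3 is estimated at 60 nM, between 20 nM and 200 nM.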

Compound 3, effective concentration (reported as EC, without a stated level of effect): 14 nM
The estimate for compound 3 lay 4.3-fold (0.63 log units) above the measured number, outside the stated range (below it).
By their numbers in this assay, from the lowest: compounds 3 and 1 (each within the scatter of the next); then compound 2.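

In this assay, 4-hydroxypiperidin-1-yl in place of 4-(carbamoylmethyl)piperazin-1-yl on this aromatic carbon gives a 3.1-fold lower number from compound 2 to compound 3 (0.50 log units; beyond the scatter), so an amide is not required here for activity at small amounts. Hydroxy in place of 2-carbamoylethyl on the saturated ring carbon gives a 1.3-fold lower number from compound 1 to compound 3 (0.11 log units; within the scatter), so the two groups cannot be told apart in this assay. No supporting data explain these results. As far as these compounds go, the first step changes the ring and its side chain together, so their separate contributions remain unknown. From the compounds shown here alone, whether an amine or a carboxylic acid on that saturated ring carbon would perform equally well also remains open.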